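From Ethyl to Phenyl on the Shared Core

The source may hold more compounds than are shown below. What is called first, only, known or untested is meant among the compounds shown, and "the series" means these compounds.

For the measured compounds named here, compound 1 `CCc1nc(Cl)ncc1C(=O)Nc1cc(C(F)(F)F)cc(C(F)(F)F)c1` is the only compound of this pair with a full number in an assay on Jurkat cells for activation of nuclear factor NF-kappa-B complex (Homo sapiens); on this read-out lower numbers stand for stronger inhibition and higher numbers for weaker inhibition; in that assay compound 1 gives 400 nM. Compound 2 `O=C(Nc1cc(C(F)(F)F)cc(C(F)(F)F)c1)c1cc(C(F)(F)F)nc(Cl)n1` belongs to the same series but differs from compound 1 in more than one place. Compound 2 reaches only the limit of this assay, > 10000 nM, and no number is known for it. Thus compound 1 stands alone as the single measured value, the other entry being the limit at which one of the two values sits (the limit of > 10000 nM in this assay, at which 1 of the 2 values shown sits).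

Compound 3 `O=C(Nc1cc(C(F)(F)F)cc(C(F)(F)F)c1)c1cnc(Cl)nc1-c1ccccc1` has not yet been measured. It differs from compound 1 by phenyl in place of ethyl on an aromatic carbon: a phenyl in place of an ethyl on an aromatic carbon of the shared core. Going by the values given here, no measured pair in this set shows a change of this kind, so the size of the step is open. He expects the step from compound 1 to compound 3 in this assay to be a modest loss of potency, somewhat beyond the usual scatter, a 2.3-fold higher number from compound 1 to compound 3 (0.35 log units; beyond the scatter). For compound 3 he therefore estimates 900 nM, with a likely range from 200 nM to 4000 nM.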

Compound 3, half-maximal inhibitory concentration: 400 nM
For compound 3 the middle estimate is 2.3-fold (0.35 log units) above the measured one, and the stated range covers the measured number.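

At this position, on an aromatic carbon next to the ring nitrogen, the shared core takes phenyl in place of ethyl, so that a six-membered aromatic ring enters where no ring stood, and in this assay the read-out stays put (no change at the digits printed from compound 1 to compound 3 (within the scatter)). For the compounds shown here, the earlier compounds offered no step between compounds differing in one place, so this pair gives the first reading of a single change on the shared core: here, a group of 6 heavy atoms does as well as one of 2. No measurement given here bears on why the two groups give the same read-out.

As far as these compounds go, whether this tolerance extends to other groups at this position, such as an amine, a methoxy group or a longer chain like n-butyl, or to a phenyl carrying a substituent of its own, stays open. Compound 2, whose > 10000 nM is a limit of the assay, differs from compound 1 in more than one place and so cannot show what any single change on the shared core does.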